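Moving the fluorine on the anilide ring

The compounds below may be only part of what the source reports. "The series", "measured", "known", "first", "only" and "open" are said of these compounds alone.

In a functional assay on HeLa cells (Homo sapiens) for inhibition, read by MTT assay, with a stated time of 24 h (on this read-out lower numbers stand for stronger inhibition and higher numbers for weaker inhibition), compound 3 (`CCOC(=O)C1=Cc2ccccc2OC1(OCc1cn(CC(=O)Nc2ccccc2F)nn1)C(F)(F)F`) gives 49900 nM. Among the two numbers shown this is the lower one, with compound 1 (`CCOC(=O)C1=Cc2ccccc2OC1(OCc1cn(CC(=O)Nc2ccc(C)cc2)nn1)C(F)(F)F`) nearest at 67400 nM; the step of a 1.4-fold lower number from compound 1 to compound 3 (0.13 log units; within the scatter) lies within the scatter, so the two cannot be told apart. For compound 2 (`CCOC(=O)C1=Cc2ccccc2OC1(OCc1cn(CC(=O)Nc2ccccc2Br)nn1)C(F)(F)F`) the read-out is > 150000 nM, which is a limit of the assay, namely (the limit of > 150000 nM in this assay, at which 1 of the 3 values shown sits). The steps of an at least 2.2-fold higher number from compound 1 to compound 2 (0.34 log units; beyond the scatter) and an at least 3.0-fold lower number from compound 2 to compound 3 (0.47 log units; beyond the scatter) concern the bromine-bearing ring and do not address where the fluorine sits.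

Compound 4 (`CCOC(=O)C1=Cc2ccccc2OC1(OCc1cn(CC(=O)Nc2cccc(F)c2)nn1)C(F)(F)F`) differs from compound 3 only in that (3-fluorophenyl in place of 2-fluorophenyl on an amide-type nitrogen). Within the data shown here, no measured step moves a substituent around the ring; the closest guidance is that a 2-fluorophenyl and a 4-methylphenyl give numbers within the scatter of each other. A step no larger than the scatter is therefore expected, a 1.1-fold higher number from compound 3 to compound 4 (0.04 log units; within the scatter). The estimate for compound 4 in this assay is 55000 nM, with a range from 25000 nM to 130000 nM.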

Compound 4, half-maximal inhibitory concentration: > 150000 nM
Compound 4 gave a limit, no number (the forecaster's own chance of this, stated with the estimate: 15%); middle value at least 2.7-fold (0.43 log units) away from the limit.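

With the same atoms on the anilide ring, 3-fluorophenyl in place of 2-fluorophenyl gives an at least 3.0-fold higher number from compound 3 to compound 4 (0.47 log units; beyond the scatter), the only step shown that moves a substituent without changing it, so the placing of the fluorine matters in this assay. The 3-fluorophenyl group also falls behind the 4-methylphenyl group, an at least 2.2-fold higher number from compound 1 to compound 4 (0.34 log units; beyond the scatter), so a fluorine on this ring does not by itself keep a measurable number, and the 2-bromophenyl compound 2 shows that the name 2-substituted does not either. The read-out of compound 4 is a limit, as is that of compound 2, so the step between these two cannot be read: the limit of > 150000 nM in this assay, at which 2 of the 4 values shown sit.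

Open, from the compounds shown here alone, is how this ring reads with a chloro, methoxy or amino group in place of fluorine. Also open, going by these compounds, is whether a longer chain between the amide nitrogen and the ring alters the difference between 2-fluorophenyl and 3-fluorophenyl.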